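Cytotoxicity notes on a shared-core series: compound 3 to compound 4

The compounds below may be only part of what the source reports. "The series", "measured", "known", "first", "only" and "open" are said of these compounds alone.

Three compounds of the series have been run in a toxicity assay on NIH3T3 cells (Mus musculus) for cytotoxicity, read by resazurin assay; on this read-out lower numbers stand for an effect already at smaller amounts and higher numbers for an effect only at larger amounts of compound. Compound 1 `Cc1ccccc1-c1ccc(Cn2cncc2CNc2ccc(-c3nc4ccccc4s3)c(-c3ccccc3)c2)cc1` reaches only an assay limit, > 1000 nM. Compound 2 `c1ccc(-c2ccc(Cn3cncc3CNc3ccc(-c4cc5ccccc5o4)c(-c4ccccc4)c3)cc2)cc1` likewise gives a limit, > 10000 nM. Compound 3 `Nc1cc(-c2ccccc2)ccc1Cn1cncc1CNc1ccc(-c2nc3ccccc3s2)c(-c2ccccc2)c1` also stops at a limit, > 1000 nM. Compound 3 thus stands where most of the values sit, at the limit of > 1000 nM in this assay, at which 2 of the 3 values shown sit, while one value sits at the limit of > 10000 nM in this assay, at which 1 of the 3 values shown sits; no value in the set is a real number. The next compound, compound 4 `c1ccc(-c2ccc(Cn3cncc3CNc3ccc(-c4nc5ccccc5s4)c(-c4ccccc4)c3)cc2)cc1`, differs from compound 3 by hydrogen in place of amino on an aromatic carbon. Going by the values given here, no measured pair differs in one place, so no measured step is available for comparison. The step from compound 3 to compound 4 is expected to be small, a step that the limit leaves unreadable from compound 3 to compound 4, and most likely none beyond the scatter. Compound 4 is estimated at 10000 nM in this assay, with a range from 3000 nM to 30000 nM.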

Compound 4, half-maximal effective concentration: > 1000 nM
Compound 4 was reported as a limit; the forecaster's own chance of this, stated with the estimate: 80%; the middle value does not contradict the limit.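

Compound 4 ends at a limit, > 1000 nM, and its steps from compound 1, compound 2 and compound 3 cannot be read. Left open is the concentration at which any of these four compounds takes effect in this assay.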